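The source may hold more compounds than are shown below. What is called first, only, known or untested is meant among the compounds shown, and "the series" means these compounds.

Measured in a functional assay on HL-60 cells (Homo sapiens) for inhibition, read by CCK-8 assay, with a stated time of 48 h; a lower number here means a stronger inhibitor, a higher number a weaker inhibitor:
- compound 1 `O=S(=O)(NCCNC(=S)Nc1cccc(Cl)c1)c1ccc(-c2ccccc2OCc2cccc(O)c2)s1`: 1800 nM
- compound 2 `O=C(NCCNS(=O)(=O)c1sccc1-c1ccccc1Oc1ccc(O)c(O)c1)Nc1cc(Cl)cc(Cl)c1`: 6900 nM
- compound 3 `O=C(NCCNS(=O)(=O)c1ccc(-c2ccccc2O[C@H]2CC[C@@H](O)CC2)s1)Nc1cc(C(F)(F)F)cc(C(F)(F)F)c1`: 3100 nM

Of these three, compound 2 has the highest number, and its gaps to compound 3, the nearest, and compound 1, the furthest, both lie beyond the scatter. Compound 4 `CC(C)c1ccc(Oc2ccc(O)c(O)c2)c(-c2ccsc2S(=O)(=O)NCCNC(=O)Nc2cc(Cl)cc(Cl)c2)c1` carries isopropyl in place of hydrogen on an aromatic carbon. Within the data shown here, no two measured compounds differ in one place only, so the data give no direct measure of such a step. In this assay, no step beyond the scatter is expected, with a slight lean towards a lower number. The expected step is a 1.4-fold lower number from compound 2 to compound 4 (0.14 log units; within the scatter). For compound 4 the estimated value is 5000 nM, with an expected range of 2000 nM to 12000 nM.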

Compound 4, half-maximal inhibitory concentration: 6500 nM
Compound 4: the middle estimate sits 1.3-fold (0.11 log units) below what was measured; the measured number falls inside the stated range.
By their numbers in this assay, from the lowest: compounds 1 and 3 (each within the scatter of the next); then compounds 4 and 2 (each within the scatter of the next).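

In this assay, among these compounds, isopropyl in place of hydrogen on this aromatic carbon, para to the 3,4-dihydroxyphenoxy group, gives a 1.1-fold lower number from compound 2 to compound 4 (0.03 log units; within the scatter) as the only single-place step so far. On the core of compound 2, this position therefore accepts isopropyl with no shift that can be told from the scatter. No measured property bears on this result. Still open, going by these compounds, is whether a hydroxyl group, an amine or a carboxylic acid on this same carbon would move the number beyond the scatter, and whether isopropyl behaves alike on the core of compound 1.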